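Series notes: ring-nitrogen methyl versus hydrogen in the shared core

The compounds below may be only part of what the source reports. "The series", "measured", "known", "first", "only" and "open" are said of these compounds alone.

Compound 1 `COc1ccccc1/C=c1/[nH]c(=O)/c(=C\c2ccccc2OC)n(C)c1=O` carries two methoxyphenyl groups on the shared core and, in a functional assay on Huh-7 cells (Homo sapiens) for cytotoxicity, read by CCK-8 assay, with a stated time of 72 h (a lower number here means a stronger inhibitor, a higher number a weaker inhibitor), compound 1 is reported as "not active" (no number reported), without a single number. Compound 2 `C=CCn1c(=O)/c(=C\c2cc(Br)ccc2F)[nH]c(=O)/c1=C\c1ccccc1OC` is likewise reported in this assay as "not active" (no number reported). For the measured compounds named here, compound 3 `COc1ccccc1/C=c1\c(=O)[nH]/c(=C/c2cccc(Cl)c2Cl)c(=O)n1C` is the only member with a number, giving 300 nM in this assay. Compound 4 `COc1ccccc1/C=c1/[nH]c(=O)/c(=C\c2ccccc2OC)[nH]c1=O` differs from compound 1 only by hydrogen in place of methyl on an aromatic nitrogen. Going by the values given here, no measured pair shows this change, so the size of the step is unknown. With compound 1 lacking a number, compound 4 is expected to remain weak in this assay, estimated at 20000 nM, with a range from 3000 nM to 100000 nM, and a report of no activity is considered likely.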

Compound 4, half-maximal inhibitory concentration: "not active" (no number reported)
No number was reported for compound 4; there is nothing to compare the estimate with.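

Neither compound 1 nor compound 4 has a number in this assay, and no step can be read between them. The compounds shown leave open what hydrogen in place of methyl on an aromatic nitrogen does to a measurable potency. No supporting evidence bears on this result.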